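The compounds below may be only part of what the source reports. "The series", "measured", "known", "first", "only" and "open" are said of these compounds alone.

Measured compounds in a functional assay on DU-145 cells (Homo sapiens) for inhibition, read by trypan blue exclusion, with a stated time of 96 h; on this read-out higher numbers stand for weaker inhibition of growth and lower numbers for stronger inhibition of growth:
Compound 1 `O=C(/C(=C\c1c(O)cc(O)cc1O)S(=O)(=O)c1ccccc1Br)c1ccc(Br)cc1` gives 50000 nM.
Compound 2 `Cc1ccc(S/C(=C/c2c(O)cc(O)cc2O)C(=O)c2ccc(Cl)cc2)cc1` gives only a limit of the assay, > 100000 nM.
Compound 3 `Cc1ccc(S/C(=C/c2c(O)cc(O)cc2O)C(=O)c2ccc(Br)cc2)cc1` likewise gives only a limit of the assay, > 100000 nM.

Compound 3 therefore has no number of its own in this assay, only a limit, and it shares that position with compound 2 (the limit of > 100000 nM in this assay, at which 2 of the 3 values shown sit). Two measured steps lead to it. From compound 1 the step is an at least 2.0-fold higher number from compound 1 to compound 3 (0.30 log units; that floor lies within the scatter), with (4-methylphenyl)sulfanyl in place of (2-bromophenyl)sulfonyl on a double-bonded chain carbon bound to a carbonyl carbon and a double-bonded chain carbon. From compound 2 the step is a step that the two limits leave unreadable from compound 2 to compound 3, with bromo in place of chloro on an aromatic carbon.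

Compound 4 `CSc1ccc(/C=C(/Sc2ccc(C)cc2)C(=O)c2ccc(Br)cc2)cc1` differs from compound 3 in another place entirely: 4-(methylsulfanyl)phenyl in place of 2,4,6-trihydroxyphenyl on a double-bonded chain carbon bound to a double-bonded chain carbon. For the measured compounds named here, every measured compound keeps the 2,4,6-trihydroxyphenyl, so no measured step speaks to this change, and neither step above bears on it. With compound 3 already at a limit, the expectation for compound 4 in this assay is a weak result again, most likely another limit, estimated as a step of a number no higher from compound 3 to compound 4 (the limit leaves the size open). The estimate for compound 4 is 100000 nM, within a range from 20000 nM to 500000 nM.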

Compound 4, concentration for 50% growth inhibition: 50000 nM
Compound 4: the middle estimate sits 2.0-fold (0.30 log units) above what was measured; measured number inside the range.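

Replacing 2,4,6-trihydroxyphenyl with 4-(methylsulfanyl)phenyl, the first change shown at this place on the molecule, gives an at least 2.0-fold lower number from compound 3 to compound 4 (0.30 log units; that floor lies within the scatter) in this assay. Compound 4 thus has a true number rather than a limit, even though the entering group has 0 hydrogen-bond donors where the leaving group has 3, so the 2,4,6-trihydroxyphenyl group is not needed for a readable result in this assay. The real size of the change remains unknown, and the printed floor does not clear the usual scatter, because compound 3 has only a limit, not a number of its own: the limit of > 100000 nM in this assay, at which 2 of the 4 values shown sit.

The compounds shown leave open whether the difference comes from losing the hydroxyl groups or from gaining the methylsulfanyl group, since both happen in the same step. A plain phenyl ring at this place would help separate the two, while a phenyl ring carrying an amine or a carboxylic acid would show how far this position tolerates other groups.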